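The source may report more compounds than this note shows. Statements on the series, on what has been measured and on what is new or still open speak of the compounds shown alone.

Working notes on the series. In an in vitro functional assay on HEK293-A cells for antagonist activity at metabotropic glutamate receptor 5 (Rattus norvegicus), read by fluorescence and calcium flux, with a stated time of 140 s (on this read-out lower numbers stand for stronger inhibition and higher numbers for weaker inhibition), compound 1 `Cc1cccc(NC(=O)c2cccc(C#N)c2)n1` gives 490 nM, the higher of the two numbers in hand; compound 2 `Cc1cccc(NC(=O)c2cc(-c3cc(F)cc(F)c3)ccn2)n1` gives 98.1 nM, a lower number, and the gap between the two lies beyond the scatter. For compound 3 `Cc1cccc(NC(=O)c2cc(F)cc(F)c2)n1` the entry in this assay reads "not determined" (no result reported), so it adds no number. Compound 4 `Cc1cccc(NC(=O)c2ccc(-c3cccnc3)c(C#N)c2)n1` differs from compound 1 by pyridin-3-yl in place of hydrogen on an aromatic carbon, a pyridin-3-yl in place of hydrogen on an aromatic carbon. Among the measured compounds shown here, no measured pair isolates this change. The step from compound 1 to compound 4 in this assay is expected to be a modest one toward a lower number, a 2.5-fold lower number from compound 1 to compound 4 (0.39 log units; beyond the scatter), probably just beyond the scatter. Compound 4 is therefore estimated at 200 nM, within 60 nM to 700 nM.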

Compound 4, half-maximal inhibitory concentration: > 1000 nM
Compound 4: a limit, no number; the forecaster's own chance of this, stated with the estimate: 5%; middle value at least 5.0-fold (0.69 log units) from the limit.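

Compound 4 gives > 1000 nM in this assay, which is a limit of the assay and not a number. On this aromatic carbon, ortho to a cyano group, pyridin-3-yl in place of hydrogen gives an at least 2.0-fold higher number from compound 1 to compound 4 (0.30 log units; that floor lies within the scatter), so the modest gain in inhibition is not seen, though the step is not shown to exceed the scatter. The full size of the step cannot be read: the limit of > 1000 nM in this assay, at which 1 of the 4 values shown sits.

The compounds shown leave open how a methoxy group, an amine or a plain phenyl ring would read at this carbon. They also leave open whether pyridin-3-yl would read the same on another carbon of this ring.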